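Chloro for Fluoro on the Benzyl Ring of an Indolylmethanol

A few compounds are considered here, and "the series" means these few. Any claim that something is new, unique, unknown or untested is made for them only; others in the source may bear on it.

Compound 1 `O=Cc1cn(Cc2ccc(Cl)cc2)c2ccc(F)cc12` and compound 2 `O=Cc1cn(Cc2ccc(Cl)cc2)c2ccc(Cl)cc12` share a core and differ only by chloro in place of fluoro on an aromatic carbon. In a functional assay on T29Kt1 cells (Homo sapiens) for cytotoxicity, read by sulforhodamine B assay, with a stated time of 3 days (a higher number here means a weaker inhibitor, a lower number a stronger inhibitor), compound 1 gives 9090 nM, and compound 2 gives 10000 nM; the step is a 1.1-fold higher number from compound 1 to compound 2 (0.04 log units; within the scatter). Compound 3 `OCc1cn(Cc2cccc(F)c2)c2ccccc12` belongs to a different core; how its core differs from that of compound 1 is not broken down here. In this assay compound 3 gives 20 nM. Compound 4 `OCc1cn(Cc2cccc(Cl)c2)c2ccccc12` differs from compound 3 by chloro in place of fluoro on an aromatic carbon. This is the same kind of change as that from compound 1 to compound 2, not the same: there the place was part of a fused or bridged system of two rings, meta to a fused ring and para to a fused ring, whereas here it is meta to a large group on a ring of carbon only. Because a 1.1-fold higher number from compound 1 to compound 2 (0.04 log units; within the scatter) lay within the scatter, compound 4 is expected to stay close to compound 3, with an estimated step of a 1.3-fold higher number from compound 3 to compound 4 (0.10 log units; within the scatter). The estimate for compound 4 in this assay is 25 nM, from 8 nM to 80 nM.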

Compound 4, half-maximal inhibitory concentration: 160 nM
The estimate for compound 4 lay 6.4-fold (0.81 log units) below the measured number, and the stated range ends below it.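

In this assay, chloro in place of fluoro gives an 8.0-fold higher number from compound 3 to compound 4 (0.90 log units; beyond the scatter), so the change that stayed within the scatter on the core of compound 1 does not stay there on the core of compound 3. Among the compounds shown here, the result therefore does not carry from one core to the other: the same change on two cores in this assay, a 1.1-fold higher number (0.04 log units; within the scatter) from compound 1 to compound 2 and an 8.0-fold higher number (0.90 log units; beyond the scatter) from compound 3 to compound 4, 7.3-fold (0.86 log units) apart, beyond the scatter of two such steps This does not show what sets the two steps apart, since the pairs differ both in core and in where the change sits, and each core offers only one pair.

The compounds shown leave open how a bromo or a methyl group at the same place on the core of compound 3 would compare. They also leave open whether a larger step would recur with an amine elsewhere on that core.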